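The source may hold more compounds than are shown below. What is called first, only, known or untested is meant among the compounds shown, and "the series" means these compounds.

Within the data shown here, only two compounds with this shared core have numbers in a functional assay on HeLa cells (Homo sapiens) for cytotoxicity, read by sulforhodamine B assay (on this read-out higher numbers stand for weaker inhibition and lower numbers for stronger inhibition), and they differ solely in the group on the sulfonyl sulfur. In this assay compound 1 `Cc1ccc(S(=O)(=O)NC(C2=CC(=O)c3c(O)ccc(O)c3C2=O)C(C)C)cc1` gives 4850 nM and compound 2 `COc1ccc(S(=O)(=O)NC(C2=CC(=O)c3c(O)ccc(O)c3C2=O)C(C)C)c(OC)c1` gives 2750 nM as its result. These two numbers lie within the usual scatter of each other, so compound 2 cannot be set apart from compound 1 on this evidence. Still unmeasured is compound 3 `CC(C)C(NS(=O)(=O)c1ccc(F)cc1)C1=CC(=O)c2c(O)ccc(O)c2C1=O`, which keeps the core of compound 2 but carries 4-fluorophenyl in place of 2,4-dimethoxyphenyl on a sulfonyl sulfur, a swap counted as 4-fluorophenyl in place of 2,4-dimethoxyphenyl on a sulfonyl sulfur in full. Among the measured compounds shown here, the one measured step that bears on this is the earlier swap on the same sulfur, where 2,4-dimethoxyphenyl took the place of 4-methylphenyl, a 1.8-fold lower number from compound 1 to compound 2 (0.25 log units; within the scatter) and it stayed within the scatter. A single step is thin evidence, but it gives no reason to expect a change beyond the scatter in this assay here. The estimated step is a 1.4-fold higher number from compound 2 to compound 3 (0.14 log units; within the scatter) and it is expected to stay within the scatter. Compound 3 is expected at 3800 nM with an estimated range from 1800 nM to 8000 nM in this test.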

Compound 3, half-maximal inhibitory concentration: 6650 nM
Compound 3: middle estimate off by 1.8-fold (0.24 log units), on the low side, within the range that was stated.
By their numbers in this assay, from the lowest: compounds 2, 1 and 3 (each within the scatter of the next, the first and the last beyond it).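

In this assay the group on the sulfonyl sulfur now produces its first step beyond the scatter: 4-fluorophenyl in place of 2,4-dimethoxyphenyl gives a 2.4-fold higher number from compound 2 to compound 3 (0.38 log units; beyond the scatter), a modest change but a real one on this evidence. Fluoro in place of methyl on an aromatic carbon gives a 1.4-fold higher number from compound 1 to compound 3 (0.14 log units; within the scatter) and stays within the scatter, so compound 2 is set apart from compound 3 but still not from compound 1, and this position has so far moved the number only over a narrow span. No measurement on hand gives a reason for the step from the 2,4-dimethoxyphenyl compound to the 4-fluorophenyl compound.

On these data alone, all three groups on the sulfur are substituted phenyl rings, so it remains open whether a phenyl ring with a single methoxy group would match compound 2 or compound 3. As far as these compounds go, it also remains open how a group of a different kind, such as a plain methyl, a cyclohexyl ring or a phenyl ring carrying an amine or a carboxylic acid, would change the number.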